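Shifting the boron-containing group of compound 2

A few compounds are considered here, and "the series" means these few. Any claim that something is new, unique, unknown or untested is made for them only; others in the source may bear on it.

In a functional assay on MDA-MB-231 cells (Homo sapiens) for antiproliferative activity, read by MTT assay, with a stated time of 72 h (a higher number here means a weaker inhibitor, a lower number a stronger inhibitor), compound 2 (`COc1cc(OC)cc(-c2cccc(NC(=O)CCc3cccc4c3B(O)OC4)c2)c1`) gives 40 nM and is the strongest of three compounds. Compound 3 (`N#Cc1cccc(-c2cccc(NC(=O)CCc3cccc4c3B(O)OC4)c2)c1`) gives 110 nM on the same scale, and compound 1 (`CC(C)c1cccc(NC(=O)CCc2cccc3c2B(O)OC3)c1`) gives 1600 nM as the highest number.

Compound 4 (`COc1cc(OC)cc(-c2cccc(NC(=O)CCc3ccc4c(c3)B(O)OC4)c2)c1`) has the same atoms as compound 2, joined differently (a group of 10 heavy atoms (7 carbon, 1 boron, 2 oxygen; one five-membered non-aromatic ring with 2 hetero atoms, one six-membered aromatic ring of carbon only) in place of a group of 10 heavy atoms (7 carbon, 1 boron, 2 oxygen; one five-membered non-aromatic ring with 2 hetero atoms, one six-membered aromatic ring of carbon only), on a saturated chain carbon, two bonds along the chain from a carbonyl carbon) in the group on a saturated chain carbon, two bonds along the chain from a carbonyl carbon.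

Among the measured compounds shown here, no measured step tests this kind of change. The closest guides come from another place, an aromatic carbon: a 40-fold lower number from compound 1 to compound 2 (1.60 log units; beyond the scatter) and a 15-fold lower number from compound 1 to compound 3 (1.16 log units; beyond the scatter) are large, while a 2.8-fold higher number from compound 2 to compound 3 (0.44 log units; beyond the scatter) is modest. They show that numbers in this small set can move widely, but not which way this change will go. Compound 2 already stands lowest at 40 nM so a modest rise in this assay is the more likely outcome, with much uncertainty. The expected change is a 3.0-fold higher number from compound 2 to compound 4 (0.48 log units; beyond the scatter) in this estimate. The estimated value of compound 4 is 120 nM and its expected range of 25 nM to 600 nM is wide.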

Compound 4, half-maximal inhibitory concentration: 21000 nM
Beside the measured number, compound 4's estimate is 180-fold (2.24 log units) below it; measured number above the stated range.
By their numbers in this assay, from the lowest: compound 2; then compound 3; then compound 1; then compound 4.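

In this assay, a 530-fold higher number from compound 2 to compound 4 (2.72 log units; beyond the scatter) comes from a change that adds and removes no atoms: the same boron-containing group is simply joined differently on the saturated chain carbon. How this group is attached therefore matters greatly, even with its atom count and ring types unchanged. The earlier compounds shown here varied only the aromatic carbon, where the largest step, a 40-fold lower number from compound 1 to compound 2 (1.60 log units; beyond the scatter), is smaller than this one. Nothing measured here explains why the number rises so far.

This change is shown only with the 3,5-dimethoxyphenyl group, so its effect alongside the 3-cyanophenyl group of compound 3 remains open. Also open, on these data alone, is whether a longer chain would restore activity to compound 4, or whether a carboxylic acid could stand in for the boron-containing group in compound 2.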